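Carbamate in place of the furanamide propyl chain

The compounds below may be only part of what the source reports. "The series", "measured", "known", "first", "only" and "open" are said of these compounds alone.

For the measured compounds named here, compound 1 `CC(C)=CCC1Cc2c(OCCCNC(=O)c3ccco3)cc(=O)n(CCCO)c2CC1(C)C` has the lower number of the two measured members. In a functional assay on PANC-1 cells (Homo sapiens) for inhibition, read by MTT assay, with a stated time of 24 h, tested at 10 uM (a higher number here means more inhibition at the concentration tested (going by the name of the read-out), a lower number less inhibition), compound 1 gives 2.1%, the lowest of the two numbers at hand, while compound 2 `CC(C)=CCC1Cc2c(OCCCOc3ccc([N+](=O)[O-])cc3)cc(=O)n(CCCO)c2CC1(C)C` gives 47.5%. Going by the values given here, the one measured step, a number 45.4 percentage points higher from compound 1 to compound 2 (beyond the scatter), shows that exchanging the group at the end of the chain can move the read-out a long way. Compound 3 `CC(C)=CCC1Cc2c(OC(=O)Nc3ccc(F)c(F)c3)cc(=O)n(CCCO)c2CC1(C)C` departs from compound 1 at the same oxygen but replaces the whole chain: (3,4-difluorophenyl)carbamoyl in place of 3-(((furan-2-yl)carbonyl)amino)propyl on an oxygen on an aromatic ring. Among the compounds with values here, no measured step matches this change directly, so the step from compound 1 to compound 2 is the only guide, and it only tells that compound 1 sits near the floor and that alterations there have so far gone upward. A modest rise is therefore expected, a number 17.9 percentage points higher from compound 1 to compound 3 (beyond the scatter), with wide uncertainty. Compound 3 is estimated at 20%, within 0% to 50%.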

Compound 3, a percentage reported as inhibition, at one concentration (the size of the read-out at that concentration, not a potency): 76.7%
Beside the measured number, compound 3's estimate is 56.7 percentage points below it; the whole stated range lies below it.
By their numbers in this assay, from the lowest: compound 1; then compound 2; then compound 3.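

In this assay the step of a number 74.6 percentage points higher from compound 1 to compound 3 (beyond the scatter) shows that the oxygen on an aromatic ring can carry a group with no propyl chain at all and still give the highest number of the three. That number lies well clear of the one for the nitrophenoxy chain of compound 2 at 47.5% and shows that a high reading at this position does not depend on keeping the chain. Nothing at hand accounts for the size of this rise.

The step replaces the link and the terminal ring together, so the shares of the carbamoyl link and of the two fluorines remain unseparated. An unsubstituted phenylcarbamoyl, or a furan-2-yl ring placed on the same carbamoyl link, would separate them.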